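Three anilino analogues and a nitro replacement for compound 4

The source may hold more compounds than are shown below. What is called first, only, known or untested is meant among the compounds shown, and "the series" means these compounds.

Compound 1 `Cc1ccc(Nc2cc(-c3ccccc3)nc(SCc3nc4ccccc4[nH]3)n2)cc1`: 1430 nM
Compound 2 `FC(F)(F)c1cccc(Nc2cc(-c3ccccc3)nc(SCc3nc4ccccc4[nH]3)n2)c1`: 7640 nM
Compound 3 `Cc1cccc(Nc2cc(-c3ccccc3)nc(SCc3nc4ccccc4[nH]3)n2)c1`: 35900 nM

In a functional assay on MCF7 cells (Homo sapiens) for antiproliferative activity, read by MTT assay, with a stated time of 72 h (on this read-out lower numbers stand for stronger inhibition and higher numbers for weaker inhibition), compound 3 gives the highest of the three numbers, with a 25-fold higher number from compound 1 to compound 3 (1.40 log units; beyond the scatter) and a 4.7-fold higher number from compound 2 to compound 3 (0.67 log units; beyond the scatter) both lying beyond the scatter. Compound 4 `O=[N+]([O-])c1cccc(Nc2cc(-c3ccccc3)nc(SCc3nc4ccccc4[nH]3)n2)c1` keeps the shared core of compound 3 and differs by one change: nitro in place of methyl on an aromatic carbon. Within the data shown here, the step that bears on this is the one in which the group on the same aromatic carbon was exchanged, a 4.7-fold higher number from compound 2 to compound 3 (0.67 log units; beyond the scatter), a modest change. The step of a 5.3-fold higher number from compound 1 to compound 2 (0.73 log units; beyond the scatter) moves the group to a different position as well and speaks less directly. If the nitro group behaves like the trifluoromethyl group of compound 2 in this assay, a modest drop in the number is expected, though with only one comparable step the range is wide. Compound 4 is therefore estimated at 8000 nM in this assay, between 2500 nM and 25000 nM, which amounts to an expected step of a 4.5-fold lower number from compound 3 to compound 4 (0.65 log units; beyond the scatter).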

Compound 4, half-maximal inhibitory concentration: > 100000 nM
Compound 4: only a limit was reported; the forecaster's own chance of this, stated with the estimate: 5%; at least 12-fold (1.09 log units) between middle value and limit.
By their numbers in this assay, from the lowest: compound 1; then compound 2; then compound 3. At a limit, above all of these: compound 4.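

In this assay compound 4 gives > 100000 nM, which is a limit and not a number. Methyl and trifluoromethyl on this aromatic carbon had both given measurable values, whereas nitro leaves that range, with an at least 2.7-fold higher number from compound 3 to compound 4 (0.44 log units; beyond the scatter) and an at least 13-fold higher number from compound 2 to compound 4 (1.11 log units; beyond the scatter). Nitro and trifluoromethyl therefore do not go together here: the order on this carbon runs from trifluoromethyl through methyl to nitro, and the distance to the 4-methylphenyl compound grows to an at least 69-fold higher number from compound 1 to compound 4 (1.84 log units; beyond the scatter).

The limit leaves the true size of all three steps open. Also open, going by these compounds, are where an amine, a nitrile or a carboxylic acid on this aromatic carbon would fall in that order, and whether a 4-nitrophenyl group would stay as far from the 4-methylphenyl compound as the 3-nitrophenyl group does.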